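The source may hold more compounds than are shown below. What is called first, only, known or untested is meant among the compounds shown, and "the series" means these compounds.

Working notes on the series. In a functional assay on A549 cells (Homo sapiens) for antiproliferative activity, read by MTT assay, with a stated time of 72 h (a higher number here means a weaker inhibitor, a lower number a stronger inhibitor), compound 3 (`COc1cc(-n2cnc3ccc(-c4cccc(F)c4)cc32)cc(OC)c1OC`) gives 5270 nM. This sits within the scatter of compound 1 (`COc1ccccc1-c1ccc2ncn(-c3cc(OC)c(OC)c(OC)c3)c2c1`) at 4320 nM, and both lie well above compound 2 (`COc1cc(-n2cnc3ccc(-c4cccc(O)c4)cc32)cc(OC)c1OC`) at 250 nM.

Compound 4 (`COc1ccc(-c2ccc3ncn(-c4cc(OC)c(OC)c(OC)c4)c3c2)cc1`) is the next analogue to read: 4-methoxyphenyl in place of 3-fluorophenyl on an aromatic carbon of the shared core, (4-methoxyphenyl in place of 3-fluorophenyl on an aromatic carbon).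

Going by the values given here, three measured steps bear on this change. Two are large and both involve the 3-hydroxyphenyl group of compound 2: a 17-fold lower number from compound 1 to compound 2 (1.24 log units; beyond the scatter) and a 21-fold higher number from compound 2 to compound 3 (1.32 log units; beyond the scatter). The third compares the two compounds without a hydroxy group, and 3-fluorophenyl in place of 2-methoxyphenyl gave only a 1.2-fold higher number from compound 1 to compound 3 (0.09 log units; within the scatter).

Among the compounds with values here, compound 4 also lacks a hydroxy group and carries a methoxyphenyl group, as compound 1 does, so the closest precedent is the small step to compound 3. Within the data shown here, no measured compound has the 4-methoxyphenyl group, so the estimate stays wide, and a pattern drawn from three compounds is weak.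

In this assay the expected change is a 1.5-fold lower number from compound 3 to compound 4 (0.18 log units; within the scatter), with no shift beyond the scatter anticipated. Compound 4 is expected at 3500 nM, with an estimated range of 800 nM to 12000 nM.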

Compound 4, half-maximal inhibitory concentration: > 10000 nM
Compound 4: no number, only a limit; the forecaster's own chance of this, stated with the estimate: 3%; middle value at least 2.8-fold (0.45 log units) from the limit.
By their numbers in this assay, from the lowest: compound 2; then compounds 1 and 3 (each within the scatter of the next). At a limit, above all of these: compound 4.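

Compound 4 gives no number in this assay, only a limit of the assay: the limit of > 10000 nM in this assay, at which 1 of the 4 values shown sits.

With 4-methoxyphenyl in place of 2-methoxyphenyl, the step shows an at least 2.3-fold higher number from compound 1 to compound 4 (0.36 log units; beyond the scatter), so at this position the place of the methoxy group on the phenyl ring changes the read-out, which compounds 1 to 3 could not show. The same position gives an at least 40-fold higher number from compound 2 to compound 4 (1.60 log units; beyond the scatter) with 4-methoxyphenyl in place of 3-hydroxyphenyl, so among these four compounds only compound 2, with its 3-hydroxyphenyl group, stands apart at a low number, whereas 4-methoxyphenyl in place of 3-fluorophenyl gives an at least 1.8-fold higher number from compound 3 to compound 4 (0.27 log units; that floor lies within the scatter), a floor that does not separate those two compounds.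

The compounds shown leave open whether the low number of compound 2 belongs to the hydroxy group itself or to its place on the ring, a question that a 4-hydroxyphenyl or a 3-methoxyphenyl group would address. On these data alone, it also stays open how far compound 4 lies past its limit, and whether a 3-aminophenyl group, with an amine where compound 2 has its hydroxy group, would follow compound 2 or compound 3.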